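The source may hold more compounds than are shown below. What is called first, only, known or untested is meant among the compounds shown, and "the series" means these compounds.

In a functional assay on HT-1080 cells (Homo sapiens) for antiproliferative activity, read by MTT assay, with a stated time of 72 h (on this read-out higher numbers stand for weaker inhibition and lower numbers for stronger inhibition), compound 1 `COc1ccc(-c2ssc(=S)c2-c2cc(OC)c(OC)c(OC)c2)cc1N` gives 834 nM and compound 3 `COc1ccc(-c2ssc(=O)c2-c2cc(OC)c(OC)c(OC)c2)cc1` gives 464 nM, two values within the usual scatter of each other. Compound 2 `COc1ccc(-c2c(-c3cc(OC)c(OC)c(OC)c3)ssc2=S)cc1[N+](=O)[O-]` gives 3550 nM, a number clearly higher than those of the other two, which means weaker inhibition. Compound 4 `COc1ccc(-c2ssc(=O)c2-c2cc(OC)c(OC)c(OC)c2)cc1[N+](=O)[O-]` differs from compound 3 in one place: nitro in place of hydrogen on an aromatic carbon. Among the compounds with values here, no measured pair shows this change alone. Within the data shown here, compound 2, at 3550 nM, is the only measured compound with a nitro group, though it also differs from compound 4 elsewhere, so a moderate rise beyond the scatter is expected in this assay. The estimated change is a 3.2-fold higher number from compound 3 to compound 4 (0.51 log units; beyond the scatter). The expected value for compound 4 is 1500 nM, with an estimated range of 450 nM to 5000 nM.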

Compound 4, half-maximal inhibitory concentration: 4220 nM
For compound 4 the middle estimate is 2.8-fold (0.45 log units) below the measured one; low and high end bracket the measured number.
By their numbers in this assay, from the lowest: compounds 3 and 1 (each within the scatter of the next); then compounds 2 and 4 (each within the scatter of the next).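

In this assay, nitro in place of hydrogen on an aromatic carbon, ortho to a methoxy group, gives a 9.1-fold higher number from compound 3 to compound 4 (0.96 log units; beyond the scatter). Within the data shown here, this is the first reading of this change on its own, and it shows that inhibition on this core is clearly weakened when nitro enters at this position. Nothing available here accounts for the loss.

On these data alone, what a hydroxyl group, a fluorine atom or a carboxylic acid would do at this same position stays open. As far as these compounds go, whether the same step would appear on a different core also stays open.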